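The compounds below may be only part of what the source reports. "The series", "measured", "known", "first", "only" and "open" are said of these compounds alone.

Compound 1 `CC(=O)c1ccc(OCc2ccc(C)cc2)cc1`: 5.96%
Compound 2 `CC(=O)c1ccc(OCc2ccc([N+](=O)[O-])cc2)cc1`: 33.8%
Compound 3 `CC(=O)c1ccc(OCc2ccccc2F)cc1`: 47.1%

In an assay on isolated protein for inhibition of Amine oxidase [flavin-containing] A (Homo sapiens), read by Amplex Red, with a stated time of 15 min, tested at 100 uM (on this read-out higher numbers stand for more inhibition at the one concentration tested (going by the name of the read-out) and lower numbers for less inhibition), compound 2 stands second highest of the three: compound 3 gives 47.1% above it, and compound 1 gives 5.96% below it. Compound 4 `CC(=O)c1ccc(OCc2ccc(C(F)(F)F)cc2)cc1` differs from compound 2 in one place: trifluoromethyl in place of nitro on an aromatic carbon. Among the compounds with values here, the only measured step on an aromatic carbon of this ring is a number 27.8 percentage points higher from compound 1 to compound 2 (beyond the scatter), a modest rise. Within the data shown here, no measured compound carries trifluoromethyl, so the pair of compound 1 and compound 2 shows only that swapping this group can shift the number modestly. A moderate downward step is therefore expected, a number 13.8 percentage points lower from compound 2 to compound 4 (beyond the scatter). Compound 4 is estimated at 20%, with a likely range from 2% to 42%.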

Compound 4, a percentage reported as inhibition, at one concentration (the size of the read-out at that concentration, not a potency): 26.4%
Compound 4: the middle estimate sits 6.4 percentage points below what was measured; low and high end bracket the measured number.
By their numbers in this assay, from the lowest: compound 1; then compounds 4 and 2 (each within the scatter of the next); then compound 3.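

In this assay, trifluoromethyl and nitro on this aromatic carbon cannot be told apart: a number 7.4 percentage points lower from compound 2 to compound 4 (within the scatter) is a step within the usual scatter. Trifluoromethyl still stands clearly apart from methyl, with a number 20.4 percentage points higher from compound 1 to compound 4 (beyond the scatter) as the step, so nitro is no longer the only group shown to do so here. Nothing measured here accounts for these differences. Still open, on these data alone, is how an amine or a carboxylic acid would read at this position, and whether trifluoromethyl would give a similar number on another carbon of the ring.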